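The compounds below may be only part of what the source reports. "The series", "measured", "known", "first", "only" and "open" are said of these compounds alone.

Compound 1 `COc1ccnc(CNc2ccc3c(c2)nc(C)n3C[C@@H](O)[C@H]2O[C@H](O)[C@@H](O)[C@H]2O)c1C` was tested in a functional assay on the whole organism (strain Sprague-Dawley) for inhibition, with Rattus norvegicus as the target, read by paw edema, with a stated time of 180 min, at a dose of 30 mg/kg by the oral route (a lower number here means a weaker effect, a higher number a stronger effect of the compound at the dose given), and in this setting compound 1 gives 58%. A second, simpler compound, compound 2 `COc1ccnc(CNc2ccc3[nH]c(C)nc3c2)c1C`, shares the same amine-linked arrangement but lacks the sugar-derived chain on the core; in this assay compound 2 gives 55%. These two numbers sit within the usual scatter of each other, so on the two numbers at hand compound 1 and compound 2 cannot be told apart, and neither can be called the stronger of the pair.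

The step of interest leads from compound 1 to compound 3 `Cc1nc2cc(NCc3ccccn3)ccc2n1C[C@@H](O)[C@H]1O[C@H](O)[C@@H](O)[C@H]1O`, which keeps the core and the sugar-derived chain of compound 1 and changes only the group carried on the linking carbon. The difference is pyridin-2-yl in place of 4-methoxy-3-methylpyridin-2-yl on a saturated chain carbon bound to a nitrogen on an aromatic ring. Among the measured compounds shown here, no step of this kind has been measured among the compounds here, so the size and direction of its effect cannot be read from a measured pair. Removing the methoxy and methyl groups from the pyridin-2-yl is expected to cost some inhibition, giving an estimated step of a number 13 percentage points lower from compound 1 to compound 3 (beyond the scatter) in this assay. Compound 3 is therefore expected to give about 45%, with a range from 25% to 65%.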

Compound 3, a percentage reported as inhibition, in the whole organism at one dose (the size of the read-out at that dose, not a potency): 52%
For compound 3 the middle estimate is 7 percentage points below the measured one; the measured number falls inside the stated range.
By their numbers in this assay, from the lowest: compounds 3, 2 and 1 (each within the scatter of the next).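

Among the compounds shown here, measured in this assay, the change at this position gives a number 6 percentage points lower from compound 1 to compound 3 (within the scatter), the first measured step of this kind. With the core and the sugar-derived chain held fixed, pyridin-2-yl in place of 4-methoxy-3-methylpyridin-2-yl therefore leaves a read-out that cannot be told apart from the original, so at this single dose the methoxy and methyl groups are not required for an effect of this size. No independent measurement here bears on why this position tolerates the change.

Going by these compounds, it remains open whether the same change would give a similar result on the simpler compound 2, which lacks the sugar-derived chain, and whether a difference in potency lies hidden behind this one oral dose and time point. It is also unknown how the read-out would respond to a different group on the pyridin-2-yl, such as an amine or a carboxylic acid, or to a phenyl ring in its place.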